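The source may hold more compounds than are shown below. What is called first, only, known or untested is meant among the compounds shown, and "the series" means these compounds.

The series consists of compound 1 `O=C(/C=C/c1ccco1)c1ccc(OCC2CO2)cc1`, compound 2 `O=C(/C=C/c1cccs1)c1ccc(OCC2CO2)cc1`, compound 3 `O=C(/C=C/c1ccc(OCC(O)CCl)cc1)c1ccco1` and the unmeasured compound 4 `O=C(/C=C/c1ccc(OCC(O)CCl)cc1)c1cccs1`. In an assay for inhibition of DNA topoisomerase 1 (Homo sapiens), with a stated time of 30 min, tested at 100 uM (a higher number here means a stronger effect of the compound at the concentration tested, a lower number a weaker effect), compound 1 gives 36.8%, compound 2 gives 0% and compound 3 gives 1.8%. The change from compound 1 to compound 2, (thiophen-2-yl in place of furan-2-yl on a double-bonded chain carbon bound to a double-bonded chain carbon), produced a step of a number 36.8 percentage points lower from compound 1 to compound 2 (beyond the scatter). Compound 3 and compound 4 carry the same kind of change, (thiophen-2-yl in place of furan-2-yl on a carbonyl carbon), but at a different place: in compound 1 the ring sits on a double-bonded chain carbon bound to a double-bonded chain carbon, whereas in compound 3 it sits on a carbonyl carbon whose other neighbour is a double-bonded chain carbon. The difference between the core of compound 1 and the core of compound 3 is not broken down here. Since compound 3 already gives 1.8%, there is little room for a downward step of the size seen from compound 1 to compound 2; the step from compound 3 to compound 4 is therefore expected to be small, about a number 0.8 percentage points lower from compound 3 to compound 4 (within the scatter). Compound 4 is estimated at 1% in this assay, between 0% and 12%.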

Compound 4, a percentage reported as inhibition, at one concentration (the size of the read-out at that concentration, not a potency): 4.3%
Compound 4: middle estimate off by 3.3 percentage points, on the low side; the measured number falls inside the stated range.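

In this assay, replacing furan-2-yl with thiophen-2-yl on a carbonyl carbon gave a step of a number 2.5 percentage points higher from compound 3 to compound 4 (within the scatter). The swap therefore did not carry over from one core to the other with the same outcome: the same change on two cores in this assay, a number 36.8 percentage points lower (beyond the scatter) from compound 1 to compound 2 and a number 2.5 percentage points higher (within the scatter) from compound 3 to compound 4, 39.3 percentage points apart, beyond the scatter of two such steps This shows only that the result of the swap differed between these two pairs; it does not show why, since the two cores differ in more than one place and that difference is not broken down, and with compound 3 already at 1.8%, a drop of the earlier size had little room to appear.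

The compounds shown carry only furan-2-yl and thiophen-2-yl at this place, so it stays open how a phenyl or pyridyl ring would read on either core. From the compounds shown here alone, it also stays open whether an amine on the side chain would change the picture, and each reading in this assay comes from a single concentration and gives no potency.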